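An Ethyl Ester Step on a Shared Core

The compounds below may be only part of what the source reports. "The series", "measured", "known", "first", "only" and "open" are said of these compounds alone.

Compound 1, `O=C(/C=C/c1ccc2c(c1)B(O)OC2)c1ccc([N+](=O)[O-])cc1`: in an ADME assay on L929 cells (Mus musculus) for cytotoxicity, read by resazurin assay, with a stated time of 72 h (a lower number here means a stronger inhibitor, a higher number a weaker inhibitor), compound 1 gives > 10 ug/mL, which is a limit of the assay.
Compound 2, `O=C(O)c1ccc(C(=O)/C=C/c2ccc3c(c2)B(O)OC3)cc1`: in this assay compound 2 gives > 10 ug/mL, which is also a limit of the assay.

Compound 2 therefore stands at the limit rather than at a number, and it is not alone there: both values shown so far sit at that limit (the limit of > 10 ug/mL in this assay, at which 2 of the 2 values shown sit). Among the compounds with values here, the one measured step, a step that the two limits leave unreadable from compound 1 to compound 2, is bounded by two limits and its size cannot be read.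

Compound 3, `CCOC(=O)c1ccc(C(=O)/C=C/c2ccc3c(c2)B(O)OC3)cc1`, is the next compound to be tested in this assay. It differs from compound 2 by ethyl in place of hydrogen on an oxygen next to a carbonyl group. Within the data shown here, the only measured step bears on this change merely by showing that two neighbouring compounds on the same core both end at the limit, so it offers no readable size and no direction to carry over. No step beyond the scatter is expected from compound 2 to compound 3 in this assay, and the expected step is a step that the limit leaves unreadable from compound 2 to compound 3. For compound 3 the estimated value in this assay is 15 ug/mL, expected to fall between 5 ug/mL and 50 ug/mL.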

Compound 3, half-maximal inhibitory concentration: > 10 ug/mL
Compound 3: a limit, no number; the forecaster's own chance of this, stated with the estimate: 65%; the middle value lies beyond the limit too.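

In this assay compound 3 gives > 10 ug/mL, which is a limit of the assay. No new step can be read among compound 1, compound 2 and compound 3, since all the values shown sit at one limit: the limit of > 10 ug/mL in this assay, at which 3 of the 3 values shown sit. The compounds shown leave open how far each lies past that limit, and whether nitro, carboxy or ethoxycarbonyl on the shared core makes any difference in this assay.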